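Adding a methyl to a chloropyridine amide series

The compounds below may be only part of what the source reports. "The series", "measured", "known", "first", "only" and "open" are said of these compounds alone.

Measured compounds:
compound 1, `CCc1cccc(NC(=O)CN2CCN(c3ccccn3)CC2)c1`, 133 nM
compound 2, `Cc1cccc(NC(=O)CN2CCN(c3ccc(Cl)cn3)CC2)c1`, "not active" (no number reported)
compound 3, `Cc1ccc(C2CCN(CC(=O)Nc3cccc(C)c3)CC2)nc1`, "not active" (no number reported)

In an assay on cells for agonist activity at D(4) dopamine receptor (Homo sapiens), read by luminescence and beta-arrestin recruitment, with a stated time of 90 min (a lower number here means that less compound is needed, a higher number that more compound is needed for the effect), compound 1 gives 133 nM. In this assay compound 2 gives "not active" (no number reported), so no single number stands for it. Compound 3 shares the amide and the 3-methylphenyl group with compound 2 but carries a different saturated ring; in this assay compound 3 also gives "not active" (no number reported). For the measured compounds named here, compound 2 therefore stands among the entries without a reported number, while compound 1, with its ethyl group and an unsubstituted pyridine, is the only compound with a measured value.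

Compound 4, `CCc1cccc(NC(=O)CN2CCN(c3ccc(Cl)cn3)CC2)c1`, is not yet measured. It differs from compound 2 by methyl in place of hydrogen on a saturated chain carbon bound to an aromatic carbon, giving 3-ethylphenyl in place of 3-methylphenyl while the chlorine on the pyridine is kept. Going by the values given here, no step between measured compounds covers this change, so the direction is open. Compound 1 shows that the ethyl group is compatible with activity, yet compound 2 shows that the chloropyridine core gives no reported number. Compound 4 is therefore expected to land at a weak value, estimated around 2000 nM, with a range from 300 nM to 15000 nM, and a real chance that this assay again reports no number.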

Compound 4, half-maximal effective concentration: "not active" (no number reported)
The entry for compound 4 holds no number, so the estimate cannot be set against anything.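

Compound 2 and compound 4 both come without a number, so no step between them can be read, and no measurement shown offers a reason for this result. From the compounds shown here alone, it remains open whether 3-ethylphenyl in place of 3-methylphenyl changes activity at all while the chlorine stays on the pyridine.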